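The source may report more compounds than this note shows. Statements on the series, on what has been measured and on what is new or still open speak of the compounds shown alone.

Working notes on the urea-linked series around the shared core.

Of the compounds shown here, two have numbers so far. Compound 1 `COC(=O)c1cccc(Nc2ncnc3ccc(NC(=O)Nc4ccc(CN5CCN(C)CC5)cc4)cc23)c1` in a functional assay on A-431 cells (Homo sapiens) for antiproliferative activity, read by MTT assay, with a stated time of 72 h (a lower number here means a stronger inhibitor, a higher number a weaker inhibitor), gives 5630 nM. Compound 2 `O=C(Nc1ccc(CN2CCCCC2)cc1)Nc1ccc2ncnc(Nc3cccc(C(F)(F)F)c3)c2c1` in this assay gives 1550 nM. Within the data shown here, on these two numbers compound 2 stands lowest, and the gap to compound 1 lies beyond the scatter; the two differ in more than one place, so no single step between them is counted here.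

Compound 3 `Cc1ccc(NC(=O)Nc2ccc3ncnc(Nc4cccc(C(F)(F)F)c4)c3c2)cc1` has not yet been measured in this assay. It differs from compound 2 in one place: hydrogen in place of piperidin-1-yl on a saturated chain carbon bound to an aromatic carbon. The change removes the only ring bearing a hydrogen-bond acceptor on that arm and leaves a methyl in its place; the rest of the molecule, including the trifluoromethyl-bearing aniline and the urea, is kept.

Among the measured compounds shown here, no measured pair in the set isolates this change, so the expectation rests on compound 2 alone. The step from compound 2 to compound 3 is expected to be a 2.3-fold higher number from compound 2 to compound 3 (0.35 log units; beyond the scatter), toward a higher number, of modest size but likely beyond the scatter. Compound 3 in this assay is estimated at 3500 nM, within a range from 1200 nM to 10000 nM.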

Compound 3, half-maximal inhibitory concentration: > 10000 nM
Compound 3 gave a limit, no number (the forecaster's own chance of this, stated with the estimate: 5%); at least 2.8-fold (0.45 log units) between middle value and limit.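

Among these compounds, this is the first single-place step: with the urea and the trifluoromethyl-bearing aniline kept, hydrogen in place of piperidin-1-yl on a saturated chain carbon bound to an aromatic carbon gives an at least 6.4-fold higher number from compound 2 to compound 3 (0.80 log units; beyond the scatter). The step shows that, in this assay, the activity on this arm depends on what is carried at this place, as the (piperidin-1-yl)methyl to methyl change alone moves the result beyond the scatter. Compound 3 reads > 10000 nM, which is a limit of the assay and not a number, so the step has a lower bound but no full size: the limit of > 10000 nM in this assay, at which 1 of the 3 values shown sits.

The compounds shown leave open which part of the piperidin-1-yl group matters, and whether an open-chain dimethylamino group, a morpholin-4-yl ring or a carboxylic acid at the same place would keep the activity seen with the piperidine. The effect of the 4-methylpiperazin-1-yl group in compound 1 also remains unresolved, as that compound differs from compound 2 in more than one place.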